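This account rests on a few compounds, and the source may have more. Where it says the series, first, only, none or still open, it means among the compounds named here.

Compound 1 `COc1ccc(NC(=O)c2ccc3ccccc3n2)cc1`, compound 2 `O=C(Nc1cc(C(F)(F)F)cc(C(F)(F)F)c1)C1CCc2ccccc2N1C(=O)c1cccc(Cl)c1` and compound 3 `CCCC(=O)N1c2ccccc2CCC1C(=O)Nc1ccccc1C(F)(F)F` have been measured in a functional assay on NCI-H23 cells (Homo sapiens) for cytotoxicity, read by sulforhodamine B assay, with a stated time of 72 h; on this read-out lower numbers stand for stronger inhibition of growth and higher numbers for weaker inhibition of growth. Compound 1 gives 7650 nM. Compound 2 gives 420 nM, the lower of the two numbers recorded, and compound 1 stands well above it, beyond the usual scatter. Compound 3 is recorded only as a limit, > 70000 nM, in keeping with the limit of > 70000 nM in this assay, at which 1 of the 3 values shown sits.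

Compound 4 `CCC(=O)N1c2ccccc2CCC1C(=O)Nc1cc(C(F)(F)F)cc(C(F)(F)F)c1` has not yet been measured in this assay. It differs from compound 2 at a single place: ethyl in place of 3-chlorophenyl on a carbonyl carbon. For the measured compounds named here, compound 3 likewise lacks a six-membered aromatic ring on the carbonyl carbon attached to the amide-type nitrogen in the ring, whereas compound 2 is the only compound carrying a 3-chlorophenyl there. On that basis the step is expected to go toward weaker inhibition of growth, by a margin well beyond the scatter, a 21-fold higher number from compound 2 to compound 4 (1.33 log units; beyond the scatter). Compound 4 is estimated at 9000 nM, with a range from 1500 nM to 70000 nM, and with a real chance that only a limit is returned.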

Compound 4, concentration for 50% growth inhibition: 7820 nM
Compound 4: the middle estimate sits 1.2-fold (0.06 log units) above what was measured; low and high end bracket the measured number.
By their numbers in this assay, from the lowest: compound 2; then compounds 1 and 4 (each within the scatter of the next). At a limit, above all of these: compound 3.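

In this assay, for the compounds shown here, the change from 3-chlorophenyl to ethyl on a carbonyl carbon whose other neighbour is an amide-type nitrogen in a ring gives the first direct reading at this place, and the step is large: a 19-fold higher number from compound 2 to compound 4 (1.27 log units; beyond the scatter). The 3-chlorophenyl group is thus tied to the lower number of compound 2, yet with ethyl in its place compound 4 still returns a number rather than a limit. Compound 3 alone is recorded as a limit: the limit of > 70000 nM in this assay, at which 1 of the 4 values shown sits.

The compounds shown do not tell whether the chlorine or the ring itself accounts for the step, which a plain phenyl, a cyclohexyl or a longer chain at this place could separate. Nor do they show whether the step holds with other groups on the second amide of the shared core.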